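The compounds below may be only part of what the source reports. "The series", "measured", "known", "first", "only" and "open" are said of these compounds alone.

Measured so far in a functional assay for inhibition, with Homo sapiens as the target; a lower number here means a stronger inhibitor, a higher number a weaker inhibitor; every value recorded is a limit of the assay, not a number:

compound 1, `Cc1ncn2c(S)nncc12`: compound 1 gives > 48000 nM
compound 2, `CCCc1ncn2c(S)nncc12`: compound 2 gives > 48000 nM
compound 3, `CCCc1ncn2c(SC)nncc12`: compound 3 gives > 48000 nM

For the measured compounds named here, all three values sit at the limit of > 48000 nM in this assay, at which 3 of the 3 values shown sit, so no compound in the set can be ranked against another. From compound 2 to compound 1 the change is hydrogen in place of ethyl on a saturated chain carbon bound to an aromatic carbon; the step is a step that the two limits leave unreadable from compound 2 to compound 1. From compound 2 to compound 3 the change is methyl in place of hydrogen on a sulfur, and the step is a step that the two limits leave unreadable from compound 2 to compound 3; this same change is also what separates the core of compound 3 and compound 4 from the core of compound 2 and compound 1.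

Compound 4, `CSc1nncc2c(C)ncn12`, remains to be measured in this assay. It differs from compound 3 by hydrogen in place of ethyl on a saturated chain carbon bound to an aromatic carbon, the same change as from compound 2 to compound 1, made at the same place. That earlier step could not be read, since both ends of it are limits, so there is no measured size to carry over.

The expectation for compound 4 rests only on the fact that compound 3 gives a limit in this assay, and that the same change made from compound 2 to compound 1 left compound 1 at a limit as well. Compound 4 is therefore expected to stay at the limit too, with an expected step from compound 3 of a step that the limit leaves unreadable from compound 3 to compound 4. The estimate for compound 4 in this assay is 80000 nM, with a range from 25000 nM to 300000 nM.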

Compound 4, half-maximal inhibitory concentration: > 48000 nM
Compound 4 ended at the assay's limit; the forecaster's own chance of this, stated with the estimate: 85%; the middle value does not contradict the limit.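

In this assay compound 4 gives > 48000 nM, which is a limit of the assay and not a number. The steps to compound 4 from compound 3 and from compound 1 therefore cannot be read: the limit of > 48000 nM in this assay, at which 4 of the 4 values shown sit.

The compounds shown leave open whether hydrogen in place of ethyl, or methyl in place of hydrogen on a sulfur, changes inhibition at all.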